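Swapping methoxy for nitro, with little to go on

The compounds below may be only part of what the source reports. "The series", "measured", "known", "first", "only" and "open" are said of these compounds alone.

In a functional assay on SK-OV-3 cells (Homo sapiens) for cytotoxicity, read by spectrophotometry, with a stated time of 72 h (on this read-out higher numbers stand for weaker inhibition and lower numbers for stronger inhibition), compound 2 `COc1ccc(-n2c(-c3cc(OC)c(OC)c(OC)c3)cccc2=O)cc1` gives 1540 nM and compound 1 `COc1ccc(-n2c(-c3cc(OC)c(OC)c(OC)c3)cccc2=O)cc1O` gives 1220 nM, so these two cannot be told apart. Compound 3 `COc1cc(-c2cccc(=O)n2-c2ccc([N+](=O)[O-])cc2)cc(OC)c1OC` has not been measured yet. Compared with compound 2, it carries nitro in place of methoxy on an aromatic carbon, para to a large group: nitro in place of methoxy on an aromatic carbon. For the measured compounds named here, the only measured step, a 1.3-fold higher number from compound 1 to compound 2 (0.10 log units; within the scatter), puts hydrogen in place of hydroxy and stays within the scatter. Going by the values given here, that step leaves the methoxy untouched, so no measurement yet tests the group that changes here, and it offers only weak guidance. A moderate move toward weaker inhibition is expected, but this is a cautious guess: the expected change is a 2.6-fold higher number from compound 2 to compound 3 (0.41 log units; beyond the scatter). For compound 3 the estimated value is 4000 nM, with an expected range of 1000 nM to 15000 nM.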

Compound 3, half-maximal inhibitory concentration: 311 nM
For compound 3 the middle estimate is 13-fold (1.11 log units) above the measured one; the measured number lies below the stated range.
By their numbers in this assay, from the lowest: compound 3; then compounds 1 and 2 (each within the scatter of the next).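

In this assay, for the compounds shown here, replacing 4-methoxyphenyl with 4-nitrophenyl gives a 5.0-fold lower number from compound 2 to compound 3 (0.69 log units; beyond the scatter) and is the first change here to clear the scatter, so this spot, para to a large group, does respond to what sits on it. The step from the hydroxy-bearing compound tells the same story: swapping its whole ring for 4-nitrophenyl gives a 3.9-fold lower number from compound 1 to compound 3 (0.59 log units; beyond the scatter) and lands in the same modest range. Nothing available explains why nitro gives the stronger inhibition.

The compounds shown leave open whether this gain belongs to nitro alone or whether an amine, a nitrile or a carboxylic acid at the same spot would shift the number as far. They also leave open whether the step would hold on the core with a different ring in place of its trimethoxyphenyl group.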